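Adding a tert-butyl group far from the basic centre

The source may hold more compounds than are shown below. What is called first, only, known or untested is meant among the compounds shown, and "the series" means these compounds.

The two measured compounds share one core that carries a secondary amine, and the read-out is a physicochemical assay for acid dissociation. Compound 1, `CCC(CC)c1ccc2c(NCCCNCc3cccc(OC)c3O)ccnc2c1`, gives 9.47. Compound 2, `COc1cccc(CNCCCNc2ccnc3cc(Oc4ccccc4)ccc23)c1O`, gives 9.28. Of the two numbers compound 2 holds the lower one, but the two values sit within the scatter of each other, so nothing separates them in a meaningful way.

Among the measured compounds shown here, the only measured step that changed a ring substituent on the shared core is a number 0.19 log units lower from compound 1 to compound 2 (within the scatter), a change that stayed within the scatter.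

Compound 3 is `COc1cccc(CNCCCNc2ccnc3cc(Oc4ccc(C(C)(C)C)cc4)ccc23)c1O`. It differs from compound 2 by tert-butyl in place of hydrogen on an aromatic carbon. This new group sits on the outer ring that was itself introduced in the step from compound 1 to compound 2, a region where that step gave no change beyond the scatter. Since the outer ring did not move the number, a further group on it is expected to leave it where it is, so the step is estimated as a number 0.02 log units higher from compound 2 to compound 3 (within the scatter). For compound 3 the value is therefore expected to be 9.3, within a range from 9 to 9.6.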

Compound 3, acid dissociation constant: 9.28
Beside the measured number, compound 3's estimate is 0.02 log units above it; measured number inside the range.
By their numbers in this assay, from the lowest: compounds 2, 3 and 1 (each within the scatter of the next).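

In this assay, the tert-butyl group on an aromatic carbon para to a large group gives no change at the digits printed from compound 2 to compound 3 (within the scatter), so a substituent on the outer ring can now be added to the earlier phenoxy result, and the number still stays within the scatter. The full replacement of pentan-3-yl by 4-(tert-butyl)phenoxy gives a number 0.19 log units lower from compound 1 to compound 3 (within the scatter), which shows that the outer ring and its tert-butyl group together leave the reading as close to that of compound 1 as phenoxy alone did. No supporting evidence is available to explain why this reading holds steady.

The compounds shown leave open whether an amine or a carboxylic acid on the outer ring, in place of tert-butyl, would also stay within the scatter. They also leave open whether a longer chain in place of phenoxy on the shared core would keep the number in the same range.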